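Methyl for Fluoro: Expecting the Value of Compound 4

This account rests on a few compounds, and the source may have more. Where it says the series, first, only, none or still open, it means among the compounds named here.

Three compounds have been measured in a functional assay on MCF7 cells (Homo sapiens) for cytotoxicity, read by MTT assay, with a stated time of 24 h; on this read-out lower numbers stand for stronger inhibition and higher numbers for weaker inhibition:

Compound 1 `Cc1ccc2oc(-c3ccc(NC(=O)CCl)cc3)nc2c1` gives 4620 nM
Compound 2 `O=C(CCl)Nc1ccc(-c2nc3cc(F)ccc3o2)cc1` gives 3260 nM
Compound 3 `Cc1cc(-c2nc3cc(F)ccc3o2)ccc1NC(=O)CN1CCN(CCCN(C)C)CC1` gives 7770 nM

Compound 1 and compound 2 differ in one place only, by methyl in place of fluoro on an aromatic carbon. That change made a step of a 1.4-fold higher number from compound 2 to compound 1 (0.15 log units; within the scatter), so the two numbers cannot be told apart. Compound 3 carries a different amide part than compound 2; the difference between the two cores is not broken down here. Compound 3 shows the highest of the three numbers, though it lies within the scatter of compound 1 and beyond it only against compound 2.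

Compound 4 `Cc1ccc2oc(-c3ccc(NC(=O)CN4CCN(CCCN(C)C)CC4)c(C)c3)nc2c1` has not yet been measured. It differs from compound 3 by methyl in place of fluoro on an aromatic carbon, the same change, at the same place, as from compound 2 to compound 1. Because the earlier step of a 1.4-fold higher number from compound 2 to compound 1 (0.15 log units; within the scatter) stayed within the scatter, the step from compound 3 to compound 4 is expected to be small as well, about a 1.3-fold higher number from compound 3 to compound 4 (0.11 log units; within the scatter). Compound 4 is therefore estimated at 10000 nM, between 4000 nM and 25000 nM.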

Compound 4, half-maximal inhibitory concentration: 19800 nM
The estimate for compound 4 lay 2.0-fold (0.30 log units) below the measured number; the range from low to high includes it.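

In this assay, methyl in place of fluoro on the core of compound 3 gives a 2.5-fold higher number from compound 3 to compound 4 (0.41 log units; beyond the scatter). Taken alone, this step can be read as a real change, whereas the earlier step on the other core could not. Even so, the two steps point the same way and cannot be told apart, so as far as these two pairs show, the change carries over from one core to the other: the same change on two cores in this assay, a 1.4-fold higher number (0.15 log units; within the scatter) from compound 2 to compound 1 and a 2.5-fold higher number (0.41 log units; beyond the scatter) from compound 3 to compound 4, 1.8-fold (0.25 log units) apart, within the scatter of two such steps. Two pairs make no general rule, however, and they do not explain why one step falls within the scatter and the other beyond it.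

The compounds shown carry only fluoro or methyl at this place, so what chloro, methoxy or an amine would do there stays open. Also open, going by these compounds, is whether the step would hold with a different amide part, such as one ending in a carboxylic acid.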